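Series notes: aryl amide on the shared core, two measurements

This account rests on a few compounds, and the source may have more. Where it says the series, first, only, none or still open, it means among the compounds named here.

Two compounds share the core of compound 1 `CS(=O)(=O)c1ccc(C(=O)Nc2ccc(Cl)c(-c3nnc4c(Cl)cccn34)c2)c(Cl)c1` and differ only in the acyl part of the amide. In a functional assay on U-251 cells (Homo sapiens) for antiproliferative activity, read by MTT assay, with a stated time of 72 h (a higher number here means a weaker inhibitor, a lower number a stronger inhibitor), compound 1 gives 44600 nM. Compound 2 `Cc1nc(C(=O)Nc2ccc(Cl)c(-c3nnc4c(Cl)cccn34)c2)cs1` carries a methylthiazole in that position; in this assay compound 2 gives 74300 nM. The two numbers lie within the usual scatter of each other, so neither compound is set apart from the other on what has been measured, and both sit in the weak range of this assay.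

Compound 3 `O=C(Nc1ccc(Cl)c(-c2nnc3c(Cl)cccn23)c1)c1ccc(C(F)(F)F)cc1Cl` keeps the aroyl amide of compound 1 and changes one group on it: trifluoromethyl in place of methylsulfonyl on an aromatic carbon. For the measured compounds named here, no pair of measured compounds shows this step, so its size has to be expected rather than read off. Going by the values given here, with only two weak compounds to go on, no step beyond the scatter is expected from compound 1 to compound 3 in this assay, and the estimate is written as a 1.3-fold lower number from compound 1 to compound 3 (0.11 log units; within the scatter). Compound 3 is expected to give 35000 nM in this assay, within a range of 12000 nM to 100000 nM.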

Compound 3, half-maximal inhibitory concentration: > 100000 nM
Compound 3 was reported as a limit; the forecaster's own chance of this, stated with the estimate: 15%; at least 2.8-fold (0.45 log units) between middle value and limit.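

Trifluoromethyl in place of methylsulfonyl on this aromatic carbon, meta to a chloro group and para to a large group, gives an at least 2.2-fold higher number from compound 1 to compound 3 (0.35 log units; beyond the scatter) in this assay. The value of compound 3 is a limit: > 100000 nM. The earlier pair differed in the whole acyl part and stayed within the scatter of each other, so it could not show that this single position on the aroyl amide responds to what it carries; the step now shows that it does, though its size is bounded from one side only: the limit of > 100000 nM in this assay, at which 1 of the 3 values shown sits.

For the compounds shown here, still open is how far compound 3 lies past that limit, and whether methylsulfonyl is the only group tried here that holds the level of compound 1, itself a weak compound. A nitrile, an amine or a carboxylic acid on the same aromatic carbon would show whether the hydrogen-bond acceptors that leave with methylsulfonyl follow the number, or whether the step belongs to trifluoromethyl alone.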